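From 4-cyanophenyl to 6-methoxypyridin-3-yl: a flat series so far

The source may report more compounds than this note shows. Statements on the series, on what has been measured and on what is new or still open speak of the compounds shown alone.

In a functional assay on MDA-MB-231 cells (Homo sapiens) for antiproliferative activity, read by MTT assay, with a stated time of 48 h (a lower number here means a stronger inhibitor, a higher number a weaker inhibitor), compound 2 (`C=CS(=O)(=O)N1CCN(c2ncnc3sc(-c4ccc(C#N)cc4)cc23)CC1`) gives 8050 nM and lies within the scatter of both other measured compounds: compound 1 (`C=CS(=O)(=O)N1CCN(c2ncnc3sc(-c4ccc(C(F)(F)F)cc4)cc23)CC1`) at 6410 nM and compound 3 (`C=CS(=O)(=O)N1CCN(c2ncnc3sc(-c4ccc(N5CCN(C)CC5)cc4)cc23)CC1`) at 7550 nM on the same read-out. The three steps among them each swap only the substituent on the phenyl ring. They are a 1.3-fold higher number from compound 1 to compound 2 (0.10 log units; within the scatter) for cyano in place of trifluoromethyl, a 1.2-fold higher number from compound 1 to compound 3 (0.07 log units; within the scatter) for 4-methylpiperazin-1-yl in place of trifluoromethyl, and a 1.1-fold lower number from compound 2 to compound 3 (0.03 log units; within the scatter) for 4-methylpiperazin-1-yl in place of cyano, all within the scatter.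

Compound 4 (`C=CS(=O)(=O)N1CCN(c2ncnc3sc(-c4ccc(OC)nc4)cc23)CC1`) differs from compound 2 as follows: 6-methoxypyridin-3-yl in place of 4-cyanophenyl on an aromatic carbon with 6-methoxypyridin-3-yl in place of 4-cyanophenyl on an aromatic carbon. For the measured compounds named here, this change also brings a six-membered aromatic ring with 1 hetero atom, and no measured compound carries such a ring, so that part remains untested. Resting on compound 2 and the step of a 1.1-fold lower number from compound 2 to compound 3 (0.03 log units; within the scatter) as the closest guide, no change beyond the scatter is expected in this assay and no direction is favoured. The estimated step is a 1.2-fold lower number from compound 2 to compound 4 (0.06 log units; within the scatter) and stays inside the scatter. For compound 4 the estimated value is 7000 nM with an expected range from 3500 nM to 13000 nM on this reasoning.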

Compound 4, half-maximal inhibitory concentration: 9270 nM
Estimate against measurement, compound 4: 1.3-fold (0.12 log units) below, within the range that was stated.
By their numbers in this assay, from the lowest: compounds 1, 3, 2 and 4 (each within the scatter of the next).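

In this assay, for the compounds shown here, the earlier steps changed only the substituent on a phenyl ring, whereas this change at the aromatic carbon next to the ring sulfur replaces the ring itself, bringing in a six-membered aromatic ring with 1 hetero atom. That exchange, together with the methoxy group it carries, gives a 1.2-fold higher number from compound 2 to compound 4 (0.06 log units; within the scatter) and a 1.4-fold higher number from compound 1 to compound 4 (0.16 log units; within the scatter), so the flat picture now extends from substituted phenyl groups to this 6-methoxypyridin-3-yl group. No evidence is available that would account for this insensitivity.

Still open, as far as these compounds go, is whether any group at this position can move the number beyond the scatter, for example a primary amine or a carboxylic acid on the aromatic ring, a saturated ring such as cyclohexyl in place of the aromatic ring, or a plain hydrogen on this carbon. All four compounds also share the ethenesulfonyl group, so what that group contributes in this cell assay stays unresolved until a compound with, for example, an acrylamide or a plain methanesulfonyl group in its place can be set beside them.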